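The source may report more compounds than this note shows. Statements on the series, on what has been measured and on what is new or still open speak of the compounds shown alone.

Measured compounds in a functional assay on MIA PaCa-2 cells (Homo sapiens) for inhibition, read by MTT assay, with a stated time of 3 days; a higher number here means a weaker inhibitor, a lower number a stronger inhibitor:

Compound 1, `CC(C)c1noc(N2CCN(C(=O)[C@@H]3CCCN(S(=O)(=O)c4ccc(S(=O)(=O)C(C)C)cc4)C3)CC2)n1`. In this assay compound 1 gives > 10000 nM, which is a limit of the assay rather than a number.
Compound 2, `CCN(CC)S(=O)(=O)c1ccc(S(=O)(=O)N2CCC[C@@H](C(=O)N(C)C(C)C)C2)cc1`. In this assay compound 2 gives > 10000 nM, again a limit and not a number.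
Compound 3, `CC(C)c1noc(C2CCN(C(=O)[C@@H]3CCCN(S(=O)(=O)c4ccc(S(=O)(=O)C(C)C)cc4)C3)CC2)n1`. In this assay compound 3 gives > 10000 nM, also a limit.

Compound 2 therefore stands nowhere in particular on these numbers: the only thing known of it is the limit of > 10000 nM in this assay, at which 3 of the 3 values shown sit, and the same holds for the other two. Within the data shown here, no step between measured compounds can be drawn, and none of the three can be called stronger or weaker than another.

The next compound, compound 4, is `CCN1CC(NC(=O)[C@@H]2CCCN(S(=O)(=O)c3ccc(S(=O)(=O)N(CC)CC)cc3)C2)C1`, to be measured in this assay. Compared with compound 2 the change is (1-ethylazetidin-3-yl)amino in place of isopropyl(methyl)amino on a carbonyl carbon.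

With every measured value a limit, there is nothing to anchor a direction. The expected step from compound 2 to compound 4 is a step that the limit leaves unreadable from compound 2 to compound 4, that is, none resolved beyond the scatter. The expected value for compound 4 is 15000 nM, within 3000 nM to 60000 nM, most likely again reported only as a limit.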

Compound 4, half-maximal inhibitory concentration: > 10000 nM
Compound 4: a limit, no number (the forecaster's own chance of this, stated with the estimate: 75%); the middle value is on the limit's open side.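

In this assay compound 4 gives > 10000 nM, a limit and not a number. No step from compound 2 to compound 4 can be read: the limit of > 10000 nM in this assay, at which 4 of the 4 values shown sit.

The compounds shown leave open whether (1-ethylazetidin-3-yl)amino in place of isopropyl(methyl)amino changes inhibition at all, and what any compound's actual half-maximal inhibitory concentration is.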